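Mirror Image of Compound 2 Awaits Its Test

This account rests on a few compounds, and the source may have more. Where it says the series, first, only, none or still open, it means among the compounds named here.

Of the compounds shown here, two have so far been measured in a functional assay on the whole organism with Mus musculus as the target, with stated times of 60 min and 30 min, at a dose of 3 mg/kg by the oral route; on this read-out higher numbers stand for more inhibition at the one dose given (going by the name of the read-out) and lower numbers for less inhibition. Compound 1, `Cc1ccc(F)cc1NC[C@@H]1[C@@H](c2ccc(S(N)(=O)=O)cc2)C1(C)C`, gives 0% in this assay. Compound 2, `CC1(C)[C@H](CNc2ccc(F)cc2C(F)(F)F)[C@H]1c1ccc(S(N)(=O)=O)cc1`, gives 38% in this assay. Compound 2 therefore stands highest of the two numbers, and its gap to compound 1 lies beyond the usual scatter of such measurements.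

The next compound to be measured is compound 3, `CC1(C)[C@@H](CNc2ccc(F)cc2C(F)(F)F)[C@@H]1c1ccc(S(N)(=O)=O)cc1`. Compared with compound 2, (the two compounds have the same atoms and bonds and differ only in configuration as drawn: 2 of 2 stereo elements differ (all stereocentres are inverted: mirror images); a stereocentre at a saturated ring carbon is drawn R in compound 2 and S in compound 3; a stereocentre at a saturated ring carbon is drawn R in compound 2 and S in compound 3). Among the measured compounds shown here, no pair of measured compounds differs only in this way, so no measured step shows how large an effect a full inversion of configuration has on this read-out. The expectation can rest only on the value of compound 2 and on the fact that every stereocentre is inverted.

Compound 3 is expected to give about 15% in this assay, with a likely range from 0% to 40%. That estimate means an expected step of a number 23 percentage points lower from compound 2 to compound 3 (beyond the scatter), downward and beyond the scatter, because compound 2 gives 38% and a mirror image need not keep that level.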

Compound 3, a percentage reported as inhibition, in the whole organism at one dose (the size of the read-out at that dose, not a potency): 39%
The estimate for compound 3 lay 24 percentage points below the measured number; the measured number falls inside the stated range.
By their numbers in this assay, from the lowest: compound 1; then compounds 2 and 3 (each within the scatter of the next).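

In this assay the mirror-image pair gives a number 1 percentage points higher from compound 2 to compound 3 (within the scatter) and so, at this one dose, the two forms cannot be told apart. Among the compounds shown here, this is the first measured pair in which the atoms and bonds stay fixed, so the configuration of the two ring carbons can be read on its own: the fact that compounds 2 and 3 differ only in the configuration as drawn. For this pair, inverting both stereocentres together leaves the inhibition within the usual scatter, although this is a single observation and does not establish a general rule.

A read-out at one dose gives the size of the effect at that dose rather than a potency, so the compounds shown leave open whether the two mirror images would still match across a range of doses, and what inverting only one of the two stereocentres would do. They also leave open whether the same match would hold with a carboxylic acid in place of the sulfonamide, or with a nitrile in place of the trifluoromethyl group.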